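Triazole-to-sulfonamide swap on the shared core, cytotoxicity series

The compounds below may be only part of what the source reports. "The series", "measured", "known", "first", "only" and "open" are said of these compounds alone.

Measured compounds:
- compound 1, `NS(=O)(=O)c1cc(-c2nnc(CN3CCN(Cc4ccccc4)CC3)o2)c(Cl)cc1SCc1ccccc1`, 125000 nM in a functional assay on MCF7 cells (Homo sapiens) for cytotoxicity, read by MTT assay, with a stated time of 72 h; a lower number here means a stronger inhibitor, a higher number a weaker inhibitor
- compound 2, `Cc1ccc(C)c(N2CCN(Cc3nnc(-c4cc(S(N)(=O)=O)c(SCc5ccccc5)cc4Cl)o3)CC2)c1`, 51000 nM in this assay
- compound 3, `CCOC(=O)c1cn(Cc2nnc(-c3cc(S(N)(=O)=O)c(SCc4ccccc4)cc3Cl)o2)nn1`, 150000 nM in this assay

Compound 3 gives the highest number of the three. Compound 1 sits within the scatter of compound 3, so the two cannot be ordered; compound 2 is separated from compound 3 by a gap beyond the scatter.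

Compound 4, `NS(=O)(=O)c1cc(-c2nnc(CNS(=O)(=O)c3ccc(Cl)cc3)o2)c(Cl)cc1SCc1ccccc1`, is not yet measured. Its change from compound 3 is ((4-chlorophenyl)sulfonyl)amino in place of 4-(ethoxycarbonyl)-1H-1,2,3-triazol-1-yl on a saturated chain carbon bound to an aromatic carbon.

Among the measured compounds shown here, only one measured step exists, a 2.5-fold lower number from compound 1 to compound 2 (0.39 log units; beyond the scatter), and it concerns the group on the amine nitrogen in a ring, not the group on the saturated chain carbon that is exchanged here. For the measured compounds named here, no measured step bears directly on the change from compound 3 to compound 4. Going by the values given here, what the three numbers show is a narrow band of weak inhibition across different groups on that chain carbon, so a shift no larger than the one seen from compound 1 to compound 2 is expected, with the direction uncertain.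

The estimate for compound 4 is 100000 nM, range 40000 nM to 250000 nM. The expected step is a 1.5-fold lower number from compound 3 to compound 4 (0.18 log units; within the scatter).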

Compound 4, half-maximal inhibitory concentration: 30000 nM
Compound 4: middle estimate off by 3.3-fold (0.52 log units), on the high side; the whole stated range lies above it.
By their numbers in this assay, from the lowest: compounds 4 and 2 (each within the scatter of the next); then compounds 1 and 3 (each within the scatter of the next).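

In this assay, among the compounds shown here, the group on the saturated chain carbon bound to an aromatic carbon now gives a step beyond the scatter, with a 5.0-fold lower number from compound 3 to compound 4 (0.70 log units; beyond the scatter) as the first measured step at this place; the only earlier step (a 2.5-fold lower number from compound 1 to compound 2 (0.39 log units; beyond the scatter)) concerned the amine nitrogen in a ring. The exchange alters several things at once: a carbon-only six-membered aromatic ring replaces a five-membered aromatic ring with 3 hetero atoms, sulfur and chlorine enter, the ester is lost, and the group gains 1 hydrogen-bond donor, so the step can be assigned only to the exchange as a whole and not to any one of these parts. No measurement of any property of these groups is available to account for the step.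

The compounds shown leave open which part of ((4-chlorophenyl)sulfonyl)amino goes with the lower number. A benzoylamino group would test the sulfonyl, a phenylsulfonylamino group the chlorine, and an N-methyl sulfonylamino group the amide hydrogen, each on the same chain carbon of the shared core.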